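Thiophen-2-yl in Place of Pyridin-2-yl

The source may hold more compounds than are shown below. What is called first, only, known or untested is meant among the compounds shown, and "the series" means these compounds.

Compound 1 `CC(C)(C)Cc1c(-c2ccccn2)sc(N)c1C(=O)c1ccc(Cl)cc1` was tested in an assay on CHO cells for displacement of a labelled ligand from adenosine receptor A1 (Homo sapiens), read by scintillation counting, tested at 10 uM (a lower number here means less inhibition, a higher number more inhibition at the concentration tested (going by the name of the read-out)), where compound 1 gives 1%. Two related compounds built on the same core give the same picture: compound 2 `CC(C)(C)Cc1csc(N)c1C(=O)c1cccc(C(F)(F)F)c1` gives 1%, and compound 3 `COc1ccc(-c2sc(N)c(C(=O)c3ccc(Cl)c(Cl)c3)c2CC(C)(C)C)cc1` gives 1%. All three sit level with one another at the digits shown, within the usual scatter of repeated measurements, and none displaces the labelled ligand to any notable degree at the concentration tested.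

Compound 4 `CC(C)(C)Cc1c(-c2cccs2)sc(N)c1C(=O)c1ccc(Cl)cc1` has not yet been measured. It differs from compound 1 in a single place: thiophen-2-yl in place of pyridin-2-yl on an aromatic carbon. Within the data shown here, no pair of measured compounds differs by this change alone, so the measured set gives no direct guide to its effect. Among the measured compounds shown here, the step expected is a number 1 percentage points higher from compound 1 to compound 4 (within the scatter), which amounts to none beyond the scatter, because compound 1 gives 1% and nothing among the measured values points elsewhere. Compound 4 is estimated to give 2% in this assay, with a range from -8% to 12%.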

Compound 4, a percentage reported as inhibition, at one concentration (the size of the read-out at that concentration, not a potency): 1%
Compound 4: middle estimate off by 1 percentage points, on the high side; measured number inside the range.
By their numbers in this assay, from the lowest: compounds 1, 2, 3 and 4 (each within the scatter of the next).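

In this assay, among these compounds, thiophen-2-yl in place of pyridin-2-yl gives no change at the digits printed from compound 1 to compound 4 (within the scatter) and this is the first direct reading of a single change in this set. At this position, on the aromatic carbon next to the ring sulfur, a five-membered aromatic ring with a sulfur can stand in for a six-membered aromatic ring with a nitrogen without moving the number beyond the scatter. Nothing measured here explains this result.

With both compounds showing so little inhibition, the pair cannot tell whether this position would respond to the same change in a compound that inhibits strongly. From the compounds shown here alone, whether a carboxylic acid or an aminomethyl group in this place would give a higher number remains open.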